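Opening the Oxetane: An Acyclic Ether Replaces the Ring

The source may hold more compounds than are shown below. What is called first, only, known or untested is meant among the compounds shown, and "the series" means these compounds.

Compound 1 `CC1(C#Cc2c(Cl)c3c(Cl)cc(C(N)=O)nc3n2[C@H]2CCCNC2)COC1`: 119 nM
Compound 2 `NC(=O)c1cc(Cl)c2c(Cl)c(C#CCO)n([C@H]3CCCNC3)c2n1`: 301 nM
Compound 3 `NC(=O)c1cc(Cl)c2c(Cl)c(C#CC3CNCCO3)n([C@H]3CCCNC3)c2n1`: 365 nM; 197 nM (2 entries)

Three measured compounds share one core and differ only in the group attached to a triple-bonded carbon. In a functional assay on KG-1 cells (Homo sapiens) for antiproliferative activity (a lower number here means that less compound is needed, a higher number that more compound is needed for the effect), compound 1 gives the lowest of the two single numbers. Its nearest neighbour is compound 2, reached by a 2.5-fold higher number from compound 1 to compound 2 (0.40 log units; beyond the scatter) through hydroxymethyl in place of 3-methyloxetan-3-yl on a triple-bonded carbon. Compound 3 has no single number; its repeated entries the several entries of compound 3 in this assay, 365 nM; 197 nM (2 entries) spread around the same region.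

Compound 4 `COC(C)(C)CC#Cc1c(Cl)c2c(Cl)cc(C(N)=O)nc2n1[C@H]1CCCNC1` is not yet measured. It differs from compound 1 by 2-methoxy-2-methylpropyl in place of 3-methyloxetan-3-yl on a triple-bonded carbon. Among the measured compounds shown here, the only measured step touching this position is a 2.5-fold higher number from compound 1 to compound 2 (0.40 log units; beyond the scatter), where losing the four-membered ring for a smaller group with a donor cost a modest amount. Compound 4 also gives up the ring, yet it keeps one acceptor and no donor and is slightly larger, so the change is less drastic than that step. The expected step is therefore small, if anything toward a higher number: a 1.3-fold higher number from compound 1 to compound 4 (0.13 log units; within the scatter) is the estimate for the move from compound 1 to compound 4. For compound 4 in this assay the expected value is 160 nM, within roughly 70 nM to 400 nM.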

Compound 4, half-maximal effective concentration: 172 nM
The estimate for compound 4 lay 1.1-fold (0.03 log units) below the measured number, within the range that was stated.
By their numbers in this assay, from the lowest: compounds 1, 4 and 2 (each within the scatter of the next, the first and the last beyond it).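

In this assay, 2-methoxy-2-methylpropyl in place of 3-methyloxetan-3-yl gives a 1.4-fold higher number from compound 1 to compound 4 (0.16 log units; within the scatter), so on this triple-bonded carbon an open chain with an ether oxygen does as well as the four-membered ring, and the ring itself is not needed for this read-out. The other new comparison gives a 1.8-fold lower number from compound 2 to compound 4 (0.24 log units; within the scatter), which places the open-chain ether within the scatter of both earlier compounds, even though those two lie beyond the scatter of each other, so the size of the earlier step may overstate what separates these groups. Repeated readings of a single compound give a sense of how small these gaps are: the several entries of compound 3 in this assay, 365 nM; 197 nM (2 entries)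

Every group shown at this place carries oxygen, so it remains open whether a purely carbon group such as tert-butyl, or a charged one such as a carboxylic acid, would give a similar number. A longer chain with the ether oxygen further out is also untested here, and these compounds cannot show whether the ring and the open chain would still match in any other assay.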